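The source may report more compounds than this note shows. Statements on the series, on what has been measured and on what is new or still open speak of the compounds shown alone.

Compound 1 `Cc1ccc(-c2cc3cc(C#N)c(C#N)cc3n2O)cc1` and compound 2 `COc1ccc(-c2cc3cc(C#N)c(C#N)cc3n2O)cc1` share one core and differ in a single change, (methoxy in place of methyl on an aromatic carbon). In an assay on isolated protein for inhibition of Amine oxidase [flavin-containing] B (Homo sapiens), read by fluorescence and spectrophotometry, with a stated time of 20 min (a higher number here means a weaker inhibitor, a lower number a stronger inhibitor), compound 1 gives 821 nM. In this assay compound 2 gives 1790 nM. That change made a step of a 2.2-fold higher number from compound 1 to compound 2 (0.34 log units; beyond the scatter). Compound 3 `COn1c(-c2ccc(C)cc2)c(CO)c2cc(C#N)c(C#N)cc21` is built on a different core, and the difference between the two cores is not broken down here. In this assay compound 3 gives only a limit, > 100000 nM. That limit is the limit of > 100000 nM in this assay, at which 1 of the 3 values shown sits. Compound 4 `COc1ccc(-c2c(CO)c3cc(C#N)c(C#N)cc3n2OC)cc1` has not yet been measured in this assay; it stands to compound 3 as compound 2 stands to compound 1, through the change (methoxy in place of methyl on an aromatic carbon), the same change at a place described in the same words. Because the step of a 2.2-fold higher number from compound 1 to compound 2 (0.34 log units; beyond the scatter) was modest, and compound 3 already sits at the limit, the expectation is that compound 4 will again give only a limit rather than a number. The step from compound 3 to compound 4 is therefore expected to read a step that the limit leaves unreadable from compound 3 to compound 4. In this assay compound 4 is expected to come in at 220000 nM, with a range from 100000 nM to 1000000 nM.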

Compound 4, half-maximal inhibitory concentration: > 100000 nM
Compound 4: a limit, no number; the forecaster's own chance of this, stated with the estimate: 85%; the middle value does not contradict the limit.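

In this assay compound 4 gives only a limit, > 100000 nM. Compound 3 is also held at a limit, so no step can be read between compound 3 and compound 4, and both stand at the same limit: the limit of > 100000 nM in this assay, at which 2 of the 4 values shown sit. The compounds shown leave open what methoxy in place of methyl does on the core of compound 3.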